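The compounds below may be only part of what the source reports. "The series", "measured", "known", "first", "only" and "open" are said of these compounds alone.

Measured so far in a functional assay on A549 cells (Homo sapiens) for cytotoxicity, read by MTT assay, with a stated time of 72 h; on this read-out higher numbers stand for weaker inhibition and lower numbers for stronger inhibition:
- compound 1 `O=C(CN1CCN(c2nnc(Cc3ccccc3)c3ccccc23)CC1)Nc1ccc(F)c(F)c1`: 10100 nM
- compound 2 `O=C(CN1CCN(c2nnc(Cc3ccccc3)c3ccccc23)CC1)Nc1cccc(F)c1`: 130000 nM

Of these two, compound 2 has the higher number, which makes it the weaker inhibitor of the pair. Compound 3 `O=C(CN1CCN(c2nnc(Cc3ccccc3)c3ccccc23)CC1)Nc1ccc(F)c(Cl)c1` has not yet been measured. It puts 3-chloro-4-fluorophenyl in place of 3-fluorophenyl on an amide-type nitrogen.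

Among the measured compounds shown here, only one measured step bears on this change: a 13-fold higher number from compound 1 to compound 2 (1.11 log units; beyond the scatter). There, hydrogen takes the place of fluoro on an aromatic carbon, and the step is large and beyond the scatter. Read in reverse, it shows compound 1, with one more fluoro on that ring than compound 2, giving the lower number. Compound 3 also carries more on that ring than compound 2, so it is expected to fall near compound 1. For the measured compounds named here, no measured compound here carries chloro, so the range stays wide.

A large step towards a lower number is therefore expected in this assay: a 14-fold lower number from compound 2 to compound 3 (1.16 log units; beyond the scatter). For compound 3 the estimated value is 9000 nM, with an expected range of 3000 nM to 30000 nM.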

Compound 3, half-maximal inhibitory concentration: "not active" (no number reported)
Compound 3 has no reported number here, and the estimate cannot be compared.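

In this assay compound 3 is reported as "not active" with no number, so no step can be read between compound 3 and compound 2 or compound 1. The compounds shown leave open how far 3-chloro-4-fluorophenyl differs from 3-fluorophenyl on this read-out. No supporting evidence bears on this result.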